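Swapping the difluorophenyl ring for a methylimidazole

A few compounds are considered here, and "the series" means these few. Any claim that something is new, unique, unknown or untested is made for them only; others in the source may bear on it.

Results in a functional assay for inhibition, with Homo sapiens as the target (a higher number here means a weaker inhibitor, a lower number a stronger inhibitor), are these
Compound 1 `COc1cc(OC)c(C(=O)/C=C/c2c(F)cccc2F)c(OC)c1` gives 1290 nM
Compound 2 `COc1cc(OC)c(C(=O)/C=C/c2ccc([N+](=O)[O-])cc2)c(OC)c1` gives 407 nM
Compound 3 `COc1cc(OC)c(C(=O)/C=C/c2cccc3ccccc23)c(OC)c1` gives 1350 nM

Compound 1 at 1290 nM stands level with compound 3 at 1350 nM within the usual scatter. Compound 2 at 407 nM has a clearly lower number than compound 1, so it is the stronger inhibitor of that pair.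

Compound 4 `COc1cc(OC)c(C(=O)/C=C/c2nccn2C)c(OC)c1` differs from compound 1 in one place 1-methyl-1H-imidazol-2-yl in place of 2,6-difluorophenyl on a double-bonded chain carbon bound to a double-bonded chain carbon and that place is a double-bonded chain carbon bound to a double-bonded chain carbon. For the measured compounds named here, no measured pair here differs in only one place, so nothing measured shows directly what such a swap does in this assay and no shift beyond the scatter is expected. The expected step of a 1.4-fold higher number from compound 1 to compound 4 (0.14 log units; within the scatter) is therefore small and uncertain, leaning towards a slightly higher number. For compound 4 the estimated value is 1800 nM with an expected range from 350 nM to 9000 nM in this test.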

Compound 4, half-maximal inhibitory concentration: 3800 nM
Compound 4: the middle estimate sits 2.1-fold (0.32 log units) below what was measured; the range from low to high includes it.
By their numbers in this assay, from the lowest: compound 2; then compounds 1 and 3 (each within the scatter of the next); then compound 4.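

In this assay the swap of 2,6-difluorophenyl for 1-methyl-1H-imidazol-2-yl brings a 2.9-fold higher number from compound 1 to compound 4 (0.47 log units; beyond the scatter) and so gives a weaker inhibitor. For the compounds shown here, this is the first change here made in one place only, and it shows that the group on this double-bonded chain carbon can shift inhibition beyond the usual scatter. No measurement at hand explains the shift. Still open, from the compounds shown here alone, is whether the shift comes from the imidazole ring or from its methyl group. An imidazole without the methyl, or a pyridyl group, at this place could help separate these possibilities.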